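Adding a fluoro group to a weak HDAC8 inhibitor

This account rests on a few compounds, and the source may have more. Where it says the series, first, only, none or still open, it means among the compounds named here.

Measured so far:
compound 1 `O=C1NC(=O)/C(=C\c2ccc(OCC(=O)N3N=C(c4ccccc4)CC3c3ccccc3)cc2)S1` gives 20000 nM
compound 2 `O=C1NC(=O)/C(=C\c2ccc(OCC(=O)N3N=C(c4ccccc4)CC3c3ccccc3Cl)cc2)S1` gives 29000 nM
compound 3 `O=C1NC(=O)/C(=C\c2ccc(OCC(=O)N3N=C(c4ccccc4)CC3c3ccc(C(F)(F)F)cc3)cc2)S1` gives 16000 nM

All three compounds were tested in an assay on cells for inhibition of histone deacetylase 8 (Homo sapiens), read by fluorescence, with a stated time of 30 min; a higher number here means a weaker inhibitor, a lower number a stronger inhibitor. Compound 2 cannot be separated from its two relatives on the numbers shown: the step of a 1.5-fold higher number from compound 1 to compound 2 (0.16 log units; within the scatter) and the step of a 1.8-fold lower number from compound 2 to compound 3 (0.26 log units; within the scatter) both stay within the scatter, and the same holds for the step of a 1.3-fold lower number from compound 1 to compound 3 (0.10 log units; within the scatter). On these numbers the shared core of compound 1 is a weak inhibitor, and neither a chloro group nor a trifluoromethyl group on an aromatic carbon has shifted it beyond the noise.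

Compound 4 `O=C1NC(=O)/C(=C\c2ccc(OCC(=O)N3N=C(c4ccc(F)cc4)CC3c3ccccc3Cl)cc2)S1` is the next step from compound 2. It differs by fluoro in place of hydrogen on an aromatic carbon, or, seen one bond further out, phenyl to 4-fluorophenyl. The measured steps that bear on it are the two other additions of a small group to an aromatic carbon, the step of a 1.5-fold higher number from compound 1 to compound 2 (0.16 log units; within the scatter) and the step of a 1.3-fold lower number from compound 1 to compound 3 (0.10 log units; within the scatter); both were within the scatter. On that basis no step beyond the scatter is expected in this assay for compound 4. The estimated step is a 1.1-fold lower number from compound 2 to compound 4 (0.05 log units; within the scatter). Compound 4 is therefore expected to give about 26000 nM, within a range of 12000 nM to 55000 nM.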

Compound 4, half-maximal inhibitory concentration: > 50000 nM
Compound 4: no number, only a limit; the forecaster's own chance of this, stated with the estimate: 15%; at least 1.9-fold (0.28 log units) between middle value and limit.
By their numbers in this assay, from the lowest: compounds 3, 1 and 2 (each within the scatter of the next). At a limit, above all of these: compound 4.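

Compound 4 carries no number in this assay, only a limit of the assay: the limit of > 50000 nM in this assay, at which 1 of the 4 values shown sits. Compounds 1, 2 and 3 all keep a plain phenyl at this place, so phenyl to 4-fluorophenyl is the only change shown on that group, and it reads as an at least 1.7-fold higher number from compound 2 to compound 4 (0.23 log units; that floor lies within the scatter) in this series. Only that floor is known, so the result points toward a weaker inhibitor without showing how far, and the true step could stay within the scatter or go well beyond it.

Still open is whether fluoro at this place gives a similar result without the chloro group of compound 2, since the step from compound 1, which has no chloro group, to its 4-fluorophenyl relative cannot be read from the compounds shown. Also open, on these data alone, is how other groups at this place, such as a methoxy group, an amine or a carboxylic acid, would compare, and whether any of them would give a measured number rather than a limit.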